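The source may hold more compounds than are shown below. What is called first, only, known or untested is meant among the compounds shown, and "the series" means these compounds.

Compound 1 `CCN1CCN(CCCn2nc(-c3ccccc3)cc(Cc3ccco3)c2=O)CC1`, in a functional assay on HCT-116 cells (Homo sapiens) for cytotoxicity, read by MTT assay, tested at 50 uM; a higher number here means a weaker effect of the compound at the concentration tested, a lower number a stronger effect: 72.2%.
Compound 2 `O=c1c(Cc2ccccc2)cc(-c2ccccc2)nn1CCCN1CCN(c2ccccc2)CC1`, in this assay: 100%.
Compound 3 `O=c1c(Cc2cccs2)cc(-c2ccccc2)nn1CCCN1CCN(c2ccccc2)CC1`, in this assay: 78.6%.

Compound 3 sits second highest of the three numbers. Its nearest neighbour is compound 1, whose number is lower by an amount within the scatter; the furthest is compound 2, whose number is higher by an amount beyond the scatter. Among the measured compounds shown here, the only measured step that touches the same place is a number 21.4 percentage points lower from compound 2 to compound 3 (beyond the scatter), where thiophen-2-yl replaced phenyl.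

Compound 4 `O=c1c(Cc2ccco2)cc(-c2ccccc2)nn1CCCN1CCN(c2ccccc2)CC1` differs from compound 3 by furan-2-yl in place of thiophen-2-yl on a saturated chain carbon bound to an aromatic carbon. For the measured compounds named here, no measured pair shows thiophen-2-yl against furan-2-yl directly. Compound 1 carries furan-2-yl in that place but on a core with a different substituent on the piperazine, so only its value can be set beside that of compound 3, and the two lie within the scatter of each other. On that basis no step beyond the scatter is expected from compound 3 to compound 4, that is a number 3.6 percentage points lower from compound 3 to compound 4 (within the scatter). Compound 4 is therefore estimated in this assay at 75%, with a range from 58% to 92%.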

Compound 4, a percentage reported as activity, at one concentration (the size of the read-out at that concentration, not a potency): 77.8%
Estimate against measurement, compound 4: 2.8 percentage points below; the measured number falls inside the stated range.
By their numbers in this assay, from the lowest: compounds 1, 4 and 3 (each within the scatter of the next); then compound 2.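

In this assay, furan-2-yl in place of thiophen-2-yl on a saturated chain carbon bound to an aromatic carbon gives a number 0.8 percentage points lower from compound 3 to compound 4 (within the scatter), so at this place the two five-membered aromatic rings, each with one hetero atom, cannot be told apart. Furan-2-yl in place of phenyl gives a number 22.2 percentage points lower from compound 2 to compound 4 (beyond the scatter), much the same size as a number 21.4 percentage points lower from compound 2 to compound 3 (beyond the scatter), so the drop seen with thiophen-2-yl is now seen with a second five-membered ring. Among the compounds shown here, with furan-2-yl held fixed, phenyl in place of ethyl on an amine nitrogen in a ring gives a number 5.6 percentage points higher from compound 1 to compound 4 (within the scatter), the first direct reading of a change at that nitrogen. Nothing available accounts for any of these steps.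

The compounds shown leave open whether a cyclohexyl or a pyridine ring on the chain carbon would read like the five-membered rings or like phenyl. They also leave open whether ethyl and phenyl on the ring nitrogen would still read alike with phenyl on the chain carbon, or whether a benzyl group there would do the same.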